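This account rests on a few compounds, and the source may have more. Where it says the series, first, only, none or still open, it means among the compounds named here.

Measured so far in a functional assay on A549 cells (Homo sapiens) for cytotoxicity, read by MTT assay, with a stated time of 72 h; on this read-out lower numbers stand for stronger inhibition and higher numbers for weaker inhibition:
- compound 1 `CNC(=O)c1cc(Oc2ccc(NC(=O)c3cc(-c4ccc(Cl)cc4)ncn3)cc2)ccn1` — > 100000 nM, a limit of the assay
- compound 2 `CNC(=O)c1cc(Oc2ccc(NC(=O)c3nccc(-c4cccc(Cl)c4)n3)cc2)ccn1` — > 100000 nM, a limit of the assay
- compound 3 `CNC(=O)c1cc(Oc2ccc(NC(=O)c3nccc(-c4ccc(OC)cc4)n3)cc2F)ccn1` — 16600 nM

Compound 1 sits at the limit of > 100000 nM in this assay, at which 2 of the 3 values shown sit, so only a limit and no number is known for it. Going by the values given here, compound 3 is the one compound of the three that gives a number in this assay. Compound 4 `CNC(=O)c1cc(Oc2ccc(NC(=O)c3cc(-c4ccc(OC)cc4)ncn3)cc2)ccn1` is not yet measured; it differs from compound 1 by methoxy in place of chloro on an aromatic carbon. No step between measured compounds is shown, so no measured step speaks for the size of the change. With compound 1 at a limit and compound 3 the only numbered point, any step from compound 1 to compound 4 can only be guessed as small to moderate toward stronger inhibition, with a real chance that compound 4 again reports only a limit. Compound 4 is expected at 60000 nM, within 15000 nM to 200000 nM, an expected step of an at least 1.6-fold lower number from compound 1 to compound 4 (0.22 log units; that floor lies within the scatter).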

Compound 4, half-maximal inhibitory concentration: 13500 nM
For compound 4 the middle estimate is 4.4-fold (0.65 log units) above the measured one; measured number below the stated range.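

In this assay, going by these compounds alone, methoxy in place of chloro, on a carbon para to a large group, gives an at least 7.4-fold lower number from compound 1 to compound 4 (0.86 log units; beyond the scatter) and is the first single-place step. This one change is enough to turn a limit into a number. Compound 1 reports only a limit, > 100000 nM, so the step is a floor and its true size cannot be read: the limit of > 100000 nM in this assay, at which 2 of the 4 values shown sit.

Still open, going by these compounds, is whether the oxygen or the methyl carries the step, which a hydroxyl or methyl group at this position would separate. An amine or a longer chain such as ethoxy could show whether the number moves further.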